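Fluoro in place of methyl: a small step expected

A few compounds are considered here, and "the series" means these few. Any claim that something is new, unique, unknown or untested is made for them only; others in the source may bear on it.

In an ADME assay on CCRF-CEM cells (Homo sapiens), read by XTT assay, with a stated time of 72 h (on this read-out higher numbers stand for weaker inhibition and lower numbers for stronger inhibition), compound 1 (`O=C1C=CC(=O)C1=C/C=C/c1ccccc1`) gives 4400 nM while compound 2 (`O=C1C=CC(=O)C1=Cc1ccccc1`) gives 2600 nM and compound 3 (`Cc1ccc(C=C2C(=O)C=CC2=O)cc1`) gives 2700 nM and so stands within the scatter of both other compounds. The next compound, compound 4 (`O=C1C=CC(=O)C1=Cc1ccc(F)cc1`), differs from compound 3 by fluoro in place of methyl on an aromatic carbon in one place, with fluoro in place of methyl on an aromatic carbon.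

For the measured compounds named here, one measured step bears on this position. Methyl in place of hydrogen on an aromatic carbon gave a 1.0-fold higher number from compound 2 to compound 3 (0.02 log units; within the scatter) and so left the number within the scatter. Going by the values given here, no measured compound yet carries fluoro, which leaves that single step as the only guide, and it is a weak one. On the strength of the step seen with compound 3, no change beyond the scatter is expected in this assay here. The expected size is a 1.1-fold lower number from compound 3 to compound 4 (0.03 log units; within the scatter) on this estimate. For compound 4 the estimated value is 2500 nM with an expected range from 1200 nM to 5000 nM in this read-out.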

Compound 4, half-maximal inhibitory concentration: 1600 nM
Compound 4: middle estimate off by 1.6-fold (0.19 log units), on the high side, within the range that was stated.
By their numbers in this assay, from the lowest: compounds 4, 2, 3 and 1 (each within the scatter of the next, the first and the last beyond it).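

In this assay, the place on the aromatic ring para to a group of 8 heavy atoms now has a second substituent, fluoro, alongside methyl and hydrogen. Fluoro in place of methyl gives a 1.7-fold lower number from compound 3 to compound 4 (0.23 log units; within the scatter), and fluoro in place of hydrogen gives a 1.6-fold lower number from compound 2 to compound 4 (0.21 log units; within the scatter), so both steps stay within the scatter. Together with the earlier methyl step, this means that hydrogen, methyl and fluoro at this place cannot be told apart in this read-out, and no order among the three can be claimed. The compounds shown leave open whether a larger or charged group at this place, such as an amine, a carboxylic acid or a longer chain, would move the number beyond the scatter. No evidence accompanies these numbers that could explain them.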